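The source may hold more compounds than are shown below. What is called first, only, known or untested is meant among the compounds shown, and "the series" means these compounds.

Measured so far:
- compound 1, `N#Cc1cccc([C@]23CCC(N(CCN4CC[C@@H](O)C4)C(=O)Nc4cccc(Cl)c4)CC2C3)c1` — 27 nM
- compound 2, `CC(C)N(CCN(C(=O)Nc1cccc(Cl)c1)C1CC[C@]2(c3cccc(C#N)c3)CC2C1)C(C)C` — 6 nM

Both compounds share one core and were run in a functional assay for antagonist activity at melanin-concentrating hormone receptor 1 (Homo sapiens); on this read-out lower numbers stand for stronger inhibition and higher numbers for weaker inhibition. Going by the values given here, compound 2 has the lowest number of the two; the nearest is compound 1, and the only recorded step, a 4.5-fold lower number from compound 1 to compound 2 (0.65 log units; beyond the scatter), concerns the amine on the saturated chain, not the urea end of the molecule.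

Compound 3, `CC(C)N(CCN(C(=O)Nc1cc(Cl)nc(Cl)c1)C1CC[C@]2(c3cccc(C#N)c3)CC2C1)C(C)C`, is not yet measured. It differs from compound 2 at the urea end: 2,6-dichloropyridin-4-yl in place of 3-chlorophenyl on an amide-type nitrogen. Among the compounds with values here, no measured step in this set touches that part of the molecule, so the step from compound 1 to compound 2 tells nothing directly about what the new aryl group on the amide-type nitrogen will do. There is accordingly no basis in these numbers for expecting a large shift in either direction, only the unmodified reference point of compound 2.

On that basis compound 3 is estimated at 10 nM, with a range of 3 nM to 40 nM. The estimated step is a 1.7-fold higher number from compound 2 to compound 3 (0.22 log units; within the scatter), meaning no change expected beyond the scatter, with the range kept wide for the untested position.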

Compound 3, inhibition constant: 2.4 nM
The estimate for compound 3 lay 4.2-fold (0.62 log units) above the measured number; measured number outside the range, below it.
By their numbers in this assay, from the lowest: compound 3; then compound 2; then compound 1.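

The urea end of the molecule is not a silent position: a 2.5-fold lower number from compound 2 to compound 3 (0.40 log units; beyond the scatter) in this assay, so the first change measured at the aryl group on the amide-type nitrogen moves the number beyond the scatter. The 3-chlorophenyl ring can give way to 2,6-dichloropyridin-4-yl, which has a ring hetero atom, one hydrogen-bond acceptor and a second chlorine, without any loss on this read-out, and compound 3 at 2.4 nM sets the new reference for the diisopropylamino series. No supporting data are available to account for this step.

The ring nitrogen and the second chlorine enter together, so this single step cannot assign the gain to either; a dichlorophenyl group or a pyridinyl group carrying a single chlorine on the same amide-type nitrogen would separate the two. Also open, as far as these compounds go, is whether the step holds with 3-hydroxypyrrolidin-1-yl on the chain in place of diisopropylamino, and how a methoxy group or a nitrile on the pyridine ring in place of chlorine would read.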